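This account rests on a few compounds, and the source may have more. Where it says the series, first, only, none or still open, it means among the compounds named here.

Compound 1 `CC(=O)Nc1nc(-c2cccc(NS(=O)(=O)c3ccc(C#CCO)cc3)c2)cs1` gives 48.8% in a functional assay on A-375 cells (Homo sapiens) for antiproliferative activity, read by trypan blue exclusion, with a stated time of 48 h, tested at 10 uM; on this read-out lower numbers stand for a stronger effect and higher numbers for a weaker effect at the one concentration tested.
Compound 2 `CC(=O)Nc1nc(-c2cccc(NS(=O)(=O)c3ccc(C#C[Si](C)(C)C)cc3)c2)cs1` reaches only the limit < 1% in this assay.
Compound 3 `CCCCCCCCC#Cc1ccc(S(=O)(=O)Nc2cccc(-c3csc(NC(C)=O)n3)c2)cc1` likewise reaches only the limit < 1% in this assay.

Compound 3 therefore stands at the floor of what this assay reports, shared with the limit of < 1% in this assay, at which 2 of the 3 values shown sit. Compound 4 `CCCCCC/C=C\c1ccc(S(=O)(=O)Nc2cccc(-c3csc(NC(C)=O)n3)c2)cc1` differs from it by a group of 8 heavy atoms (8 carbon; no ring) in place of a group of 10 heavy atoms (10 carbon; no ring), on an aromatic carbon. For the measured compounds named here, no measured step swaps a triple bond for a double bond; the steps that do touch this chain end, a number at least 47.8 percentage points lower from compound 1 to compound 2 (beyond the scatter) and a number at least 47.8 percentage points lower from compound 1 to compound 3 (beyond the scatter), were both large drops from compound 1, while a step that the two limits leave unreadable from compound 2 to compound 3 cannot be sized. Compound 4 is expected to give 3% in this assay, between 0% and 20%. The estimated change is thus a number at least 2 percentage points higher from compound 3 to compound 4 (that floor lies within the scatter), none beyond the scatter.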

Compound 4, a percentage reported as activity, at one concentration (the size of the read-out at that concentration, not a potency): <= 1%
Compound 4 gave a limit, no number (the forecaster's own chance of this, stated with the estimate: 65%); middle value at least 2 percentage points from the limit.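

In this assay compound 4 also reaches only a limit and not a number: the limit of <= 1% in this assay, at which 1 of the 4 values shown sits A triple bond on this aromatic carbon is therefore not required to reach that floor, since the 8-carbon chain with one double bond also gets there in place of dec-1-yn-1-yl. The change is a number at least 47.8 percentage points lower from compound 1 to compound 4 (beyond the scatter), while the steps to compound 2 and compound 3 cannot be read, as both ends are limits.

As far as these compounds go, whether a saturated decyl chain or a much shorter alkyl chain stays at this floor remains open. So does the effect of an amine or a carboxylic acid at the chain end.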